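Compound 4: a ring replaces an open chain

This account rests on a few compounds, and the source may have more. Where it says the series, first, only, none or still open, it means among the compounds named here.

Measured in an ADME assay on MT4 cells (Homo sapiens) for cytotoxicity, read by MTT assay, with a stated time of 4 days (on this read-out higher numbers stand for lower toxicity in this test and lower numbers for higher toxicity in this test), each value a limit:
- Compound 1 `Cc1c(Cc2c(F)cccc2F)nc(N2CCCC2)[nH]c1=O`: > 82000 nM
- Compound 2 `Cc1c(C(C)c2c(F)cccc2F)nc(N(C)C(C)C)[nH]c1=O`: > 81000 nM
- Compound 3 `CCCN(C)c1nc(C(C)c2c(F)cccc2F)c(C)c(=O)[nH]1`: > 78000 nM

Compound 3 gives > 78000 nM, which is a limit and not a number, as are the other two values. Compound 4 `Cc1c(C(C)c2c(F)cccc2F)nc(N2CCCC2)[nH]c1=O` carries pyrrolidin-1-yl in place of methyl(propyl)amino on an aromatic carbon. For the measured compounds named here, the only measured step, a step that the two limits leave unreadable from compound 2 to compound 3, has no readable size. Compound 1, which also carries pyrrolidin-1-yl, gives > 82000 nM, again a limit. No step beyond the scatter is therefore expected in this assay, and no direction can be read. The expected step is a step that the limit leaves unreadable from compound 3 to compound 4. For compound 4 the estimate is 85000 nM, with an expected range from 45000 nM to 160000 nM.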

Compound 4, half-maximal cytotoxic concentration: > 78000 nM
Compound 4 gave a limit, no number; the forecaster's own chance of this, stated with the estimate: 85%; the middle value lies beyond the limit too.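

For the compounds shown here, compound 4 gives only a limit, as do compound 1, compound 2 and compound 3, so no step to compound 4 can be read. The compounds shown leave open where each true value lies, and whether pyrrolidin-1-yl changes anything.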